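The compounds below may be only part of what the source reports. "The series", "measured", "known", "first", "only" and "open" are said of these compounds alone.

In an assay on membranes from CHO cells for displacement of a labelled ligand from adenosine receptor A1 (Homo sapiens), read by scintillation counting, with a stated time of 60 min, tested at 1 uM (a higher number here means more inhibition at the concentration tested (going by the name of the read-out), a lower number less inhibition), compound 3 `CCCC(=O)C1=C(C)NC(=O)NC1c1ccsc1` gives 6%, the highest of the three numbers, though its steps to both other compounds fall within the usual scatter. Compound 1 `CCCC(=O)C1=C(C)NC(=O)NC1c1ccoc1` gives 1% and compound 2 `CCCC(=O)C1=C(C)NC(=O)NC1c1cccs1` gives 2% in this assay. The steps of a number 1 percentage points higher from compound 1 to compound 2 (within the scatter), a number 5 percentage points higher from compound 1 to compound 3 (within the scatter) and a number 4 percentage points higher from compound 2 to compound 3 (within the scatter) all stay within the scatter, so the three compounds cannot be told apart and all lie close to no inhibition. Compound 4 `CCNC(=O)C1=C(C)NC(=O)NC1c1ccsc1` differs from compound 3 by ethylamino in place of propyl on a carbonyl carbon. Among the measured compounds shown here, none of the measured steps bears on this change: each of them swaps furan-3-yl, thiophen-2-yl or thiophen-3-yl on a saturated ring carbon and leaves the propylcarbonyl group untouched, so there is no measured guidance for this exchange. Since every measured compound sits near zero in this assay, the expected step is a number 2 percentage points lower from compound 3 to compound 4 (within the scatter), within the scatter. Compound 4 is therefore estimated at 4%, with a range from -8% to 18%.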

Compound 4, a percentage reported as inhibition, at one concentration (the size of the read-out at that concentration, not a potency): 3%
For compound 4 the middle estimate is 1 percentage points above the measured one; measured number inside the range.
By their numbers in this assay, from the lowest: compounds 1, 2, 4 and 3 (each within the scatter of the next).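

In this assay, among the compounds shown here, ethylamino in place of propyl on a carbonyl carbon gives a number 3 percentage points lower from compound 3 to compound 4 (within the scatter), so this carbonyl substituent, which the ring-group steps left untouched, can now be read for the first time. Bringing in a nitrogen and the amide hydrogen at this place leaves the number close to no inhibition, like those of the compounds that differ only in the ring group. Nothing on hand explains this result, and with the step inside the scatter, it marks no effect of the exchange at this place.

On these data alone, it remains open whether a longer chain, a piperidine or a carboxylic acid on this carbonyl carbon would lift the number clear of the scatter. Also open, as far as these compounds go, is whether ethylamino would read the same with furan-3-yl or thiophen-2-yl on the saturated ring carbon.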